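Quinoline series: cytotoxicity in HepG2 cells, next compound

The source may report more compounds than this note shows. Statements on the series, on what has been measured and on what is new or still open speak of the compounds shown alone.

Measured so far:
- compound 1, `COc1ccc(F)cc1CNCCCNc1ccnc2cc(C3CCCCC3)ccc12`: 2290 nM
- compound 2, `COc1ccc(-c2ccc3c(NCCCNCc4ccco4)ccnc3c2)cc1`: 6000 nM
- compound 3, `COc1ccc(F)cc1CNCCCNc1ccnc2cc(Cc3ccc(F)cc3Cl)ccc12`: 2460 nM

In an ADME assay on HepG2 cells (Homo sapiens) for cytotoxicity, read by luminescence, CellTiter-Glo and ATP content, with a stated time of 72 h (a higher number here means that more compound is needed for the effect, a lower number that less compound is needed), compound 3 gives 2460 nM, the second highest of the three numbers. Its nearest neighbour is compound 1 with 2290 nM, the two within the scatter; the furthest is compound 2 with 6000 nM, beyond the scatter. The next compound is compound 4, `COc1ccc(-c2ccc3c(NCCCNCc4cc(F)ccc4OC)ccnc3c2)cc1`. The change from compound 3 is 4-methoxyphenyl in place of 2-chloro-4-fluorobenzyl on an aromatic carbon.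

For the measured compounds named here, one measured step bears on it: the swap at the same aromatic carbon, a 1.1-fold higher number from compound 1 to compound 3 (0.03 log units; within the scatter), which moved nothing beyond the scatter. Compound 2 also carries the 4-methoxyphenyl, but it differs from compound 4 elsewhere as well, so its value is only a weak hint toward a higher number. The step to compound 4 is therefore expected to be small, a 1.3-fold higher number from compound 3 to compound 4 (0.13 log units; within the scatter), if anything upward. The estimate for compound 4 in this assay is 3300 nM, with a range from 1400 nM to 8000 nM.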

Compound 4, half-maximal effective concentration: 5960 nM
Beside the measured number, compound 4's estimate is 1.8-fold (0.26 log units) below it; low and high end bracket the measured number.
By their numbers in this assay, from the lowest: compounds 1 and 3 (each within the scatter of the next); then compounds 4 and 2 (each within the scatter of the next).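

In this assay this aromatic carbon proves sensitive to the group it carries: 4-methoxyphenyl gives a 2.4-fold higher number from compound 3 to compound 4 (0.38 log units; beyond the scatter) and a 2.6-fold higher number from compound 1 to compound 4 (0.42 log units; beyond the scatter), both beyond the scatter, unlike the swap of cyclohexyl for 2-chloro-4-fluorobenzyl, a 1.1-fold higher number from compound 1 to compound 3 (0.03 log units; within the scatter). With 4-methoxyphenyl held in place, 5-fluoro-2-methoxyphenyl for furan-2-yl on the saturated chain gives a 1.0-fold lower number from compound 2 to compound 4 (0.00 log units; within the scatter), so that change stays within the scatter. Nothing at hand accounts for the shift at the aromatic carbon.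

Open, as far as these compounds go, is whether a carboxylic acid or an amine on this aromatic carbon would follow 4-methoxyphenyl or cyclohexyl. Also open, from the compounds shown here alone, is whether a longer saturated chain would alter these steps.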